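Cytotoxicity of a pyrimidine carboxamide series on C8166 cells

This account rests on a few compounds, and the source may have more. Where it says the series, first, only, none or still open, it means among the compounds named here.

Compound 1 `CC(C)(NC(=O)OCc1ccccc1)c1nc(O)c(O)c(C(=O)N/N=C/c2ccc(F)cc2)n1` is one of two compounds with data in an ADME assay on C8166 cells (Homo sapiens) for cytotoxicity, read by MTT assay, with a stated time of 3 days; on this read-out higher numbers stand for lower toxicity in this test and lower numbers for higher toxicity in this test. In this assay compound 1 gives 378000 nM, the highest of the two numbers. Compound 2 `CC(C)(NC(=O)OCc1ccccc1)c1nc(O)c(O)c(C(=O)NCc2ccc(C(F)(F)F)cc2)n1` carries a benzyl amide with a trifluoromethyl group where compound 1 has a hydrazone; in this assay compound 2 gives 58100 nM. The measured step is a 6.5-fold lower number from compound 1 to compound 2 (0.81 log units; beyond the scatter).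

Compound 3 `CC(C)(NC(=O)OCc1ccccc1)c1nc(O)c(O)c(C(=O)NCc2ccccc2Cl)n1` is unmeasured. Relative to compound 1 the change is a group of 8 heavy atoms (7 carbon, 1 chlorine; one six-membered aromatic ring of carbon only) in place of a group of 9 heavy atoms (7 carbon, 1 nitrogen, 1 fluorine; one six-membered aromatic ring of carbon only), on an amide-type nitrogen.

Among the measured compounds shown here, only the step between compound 1 and compound 2 bears on this change, since it likewise trades the hydrazone for a benzyl amide, and it was a modest step to a lower number. Compound 3 keeps the benzyl amide pattern but with 2-chlorobenzyl in place of the trifluoromethyl-bearing group, so a step in the same direction is expected, of a similar or somewhat smaller size, with wide uncertainty as it rests on a single step. The expected step is a 3.4-fold lower number from compound 1 to compound 3 (0.54 log units; beyond the scatter). Compound 3 is therefore estimated at 110000 nM, within a range from 35000 nM to 350000 nM.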

Compound 3, half-maximal cytotoxic concentration: 53900 nM
Compound 3: the middle estimate sits 2.0-fold (0.31 log units) above what was measured; low and high end bracket the measured number.
By their numbers in this assay, from the lowest: compounds 3 and 2 (each within the scatter of the next); then compound 1.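

Compound 3 is a second benzyl amide on the amide-type nitrogen, and a 7.0-fold lower number from compound 1 to compound 3 (0.85 log units; beyond the scatter) in this assay places it with compound 2 rather than with compound 1, so the lower number no longer rests on the trifluoromethyl-bearing group alone. The two benzyl amides cannot be told apart: a 1.1-fold lower number from compound 2 to compound 3 (0.03 log units; within the scatter) comes with 2-chlorophenyl in place of 4-(trifluoromethyl)phenyl on a saturated chain carbon bound to an amide-type nitrogen, so this exchange of rings leaves the number within the scatter. Nothing available here explains why compound 1 stands apart from the two benzyl amides.

Compound 1 is the only hydrazone shown, so it remains open whether its higher number belongs to the hydrazone link or to the fluorine-bearing ring it carries. Going by these compounds, it is also open whether the level shared by compound 2 and compound 3 would hold for a benzyl ring carrying an amine or a carboxylic acid, or for a longer chain in place of the saturated chain carbon.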